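Isopropyl for 4-chlorobenzyl on the amine of compound 2

The compounds below may be only part of what the source reports. "The series", "measured", "known", "first", "only" and "open" are said of these compounds alone.

Measured so far:
Compound 1 `COc1ccc(CCCNCc2c(OC)cc(Oc3ccc(Nc4ccccc4)cc3)cc2OC)cc1` gives 14600 nM in a functional assay on SW-620 cells (Homo sapiens) for inhibition, read by MTT assay, with a stated time of 72 h; on this read-out higher numbers stand for weaker inhibition and lower numbers for stronger inhibition.
Compound 2 `COc1cc(Oc2cccc(Nc3ccccc3)c2)cc(OC)c1CNCc1ccc(Cl)cc1` gives 6340 nM in this assay.

Compound 2 stands lowest of the two numbers, and compound 1 sits beyond the scatter from it. The step to compound 3 `COc1cc(Oc2cccc(Nc3ccccc3)c2)cc(OC)c1CNC(C)C` makes one change: isopropyl in place of 4-chlorobenzyl on an amine nitrogen. Among the compounds with values here, no measured step of this kind is available, so the direction is uncertain; a smaller group replacing the aromatic one is expected to weaken inhibition modestly, beyond the scatter. The expected step is a 2.4-fold higher number from compound 2 to compound 3 (0.37 log units; beyond the scatter). Compound 3 is estimated at 15000 nM, with a range from 5000 nM to 45000 nM.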

Compound 3, half-maximal inhibitory concentration: > 20000 nM
Compound 3 gave a limit, no number; the forecaster's own chance of this, stated with the estimate: 15%; at least 1.3-fold (0.12 log units) between middle value and limit.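

Within the data shown here, compound 2 and compound 3 give the first measured step on this amine nitrogen. In this assay the exchange of 4-chlorobenzyl for isopropyl gives an at least 3.1-fold higher number from compound 2 to compound 3 (0.49 log units; beyond the scatter), so inhibition weakens when the aromatic ring and its chlorine leave together. Going by these compounds, compound 3 gives a limit, not a number, so the full size of this step stays unknown: the limit of > 20000 nM in this assay, at which 1 of the 3 values shown sits.

The compounds shown do not separate the ring from the chlorine, as a plain benzyl on this nitrogen would. On these data alone, whether a cyclohexylmethyl, with its saturated carbon ring, could stand in for 4-chlorobenzyl also stays open.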